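Three Sulfonamides at the Assay Limit, and a Fourth

The compounds below may be only part of what the source reports. "The series", "measured", "known", "first", "only" and "open" are said of these compounds alone.

Compound 1, `O=S(=O)(Nc1ccc(-c2nc3ccccc3o2)cc1)c1ccccc1C(F)(F)F`, gives only a limit, > 63000 nM, in an assay on isolated protein for inhibition of malate dehydrogenase, mitochondrial (Sus scrofa), with stated times of 45 min and 30 min; on this read-out higher numbers stand for weaker inhibition and lower numbers for stronger inhibition. Compound 2, `COc1ccc(Cl)cc1S(=O)(=O)Nc1ccc(-c2nc3ccccc3o2)cc1`, gives the limit > 63000 nM in this assay. Compound 3, `O=S(=O)(Nc1ccc(-c2nc3ccccc3o2)cc1)c1ccc(Cl)s1`, gives the limit > 63000 nM in this assay.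

Compound 3 thus stands at the limit, as do its two companions; this is the limit of > 63000 nM in this assay, at which 3 of the 3 values shown sit. Among the measured compounds shown here, the one single-site step among them, a step that the two limits leave unreadable from compound 2 to compound 3, is unreadable, since both ends are limits. Compound 4, `O=S(=O)(Nc1ccc(-c2nc3ccccc3o2)cc1)c1ccccc1F`, differs from compound 3 by 2-fluorophenyl in place of 5-chlorothiophen-2-yl on a sulfonyl sulfur. For the measured compounds named here, no measured step gives a number, so no direction can be drawn, and given the limit of > 63000 nM in this assay, at which 3 of the 3 values shown sit, compound 4 is expected to remain at the limit. Compound 4 is therefore estimated at about 100000 nM, within 30000 nM to 400000 nM. The expected step that the limit leaves unreadable from compound 3 to compound 4 is none beyond the scatter.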

Compound 4, half-maximal inhibitory concentration: > 63000 nM
Compound 4 gave a limit, no number (the forecaster's own chance of this, stated with the estimate: 85%); the middle value is on the limit's open side.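

Compound 4 also gives only a limit, so its steps from compound 1, compound 2 and compound 3 cannot be read: the limit of > 63000 nM in this assay, at which 4 of the 4 values shown sit. The compounds shown leave open how strongly any of them inhibits in this assay, and whether changing the group on the sulfonyl sulfur matters.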